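The source may hold more compounds than are shown below. What is called first, only, known or untested is meant among the compounds shown, and "the series" means these compounds.

Of the compounds shown here, two sharing a core have been tested in a functional assay on U2OS cells (Homo sapiens) for antiproliferative activity, read by MTT assay, with a stated time of 72 h; a lower number here means a stronger inhibitor, a higher number a weaker inhibitor. Compound 1 `O=C(CSc1ncc[nH]1)Nc1ccc2nc(NC(=O)c3ccc(C(F)(F)F)cc3)sc2c1` gives 18800 nM there. Compound 2 `O=C(CSc1cccc(O)c1)Nc1ccc2nc(NC(=O)c3cccs3)sc2c1` gives 63000 nM in this assay, the higher of the two numbers, and its gap to compound 1 lies beyond the usual scatter, so compound 2 is the weaker of the two. Compound 3 `Cc1ccc(C(=O)Nc2nc3ccc(NC(=O)CSc4cccc(O)c4)cc3s2)cc1` is compound 2 with one change: 4-methylphenyl in place of thiophen-2-yl on a carbonyl carbon. Among the measured compounds shown here, no measured pair shows this change on its own, so the expectation leans on compound 1, which carries a six-membered carbon-only ring on its carbonyl and gives 18800 nM. A modest drop in number is expected, as a 2.1-fold lower number from compound 2 to compound 3 (0.32 log units; beyond the scatter). Compound 3 is estimated to give 30000 nM, within 10000 nM to 100000 nM.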

Compound 3, half-maximal inhibitory concentration: 12400 nM
Compound 3: the middle estimate sits 2.4-fold (0.38 log units) above what was measured; the measured number falls inside the stated range.
By their numbers in this assay, from the lowest: compounds 3 and 1 (each within the scatter of the next); then compound 2.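

In this assay, among the compounds shown here, putting 4-methylphenyl in place of thiophen-2-yl on the carbonyl carbon gives a 5.1-fold lower number from compound 2 to compound 3 (0.71 log units; beyond the scatter) and is the first step here with only this group changed. It shows that the ring on this carbonyl can move the number beyond the scatter on its own, with the rest of the molecule held fixed. No measurement here speaks to what lies behind the step.

The compounds shown leave open whether the methyl group or the six-membered ring carries the step, which a plain phenyl would separate. As far as these compounds go, how a pyridine ring or a saturated cyclohexyl ring would fare on this carbonyl is also open.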